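The source may hold more compounds than are shown below. What is called first, only, known or untested is meant among the compounds shown, and "the series" means these compounds.

Of the compounds shown here, three have been measured in a functional assay on A549 cells (Homo sapiens) for cytotoxicity, read by sulforhodamine B assay, with a stated time of 48 h; on this read-out higher numbers stand for weaker inhibition of growth and lower numbers for stronger inhibition of growth. Compound 1 `ClCc1cccc(Cn2cnc3ncnc(Cl)c32)c1` gives 17400 nM, compound 3 `ClCc1cccc(Cn2cnc3nc(Cl)nc(Cl)c32)c1` gives 12000 nM, and compound 2 `ClCc1ccc(Cn2cnc3nc(Cl)nc(Cl)c32)cc1` gives 2130 nM, the lowest of the three, with its gaps to both other compounds lying beyond the usual scatter. Compound 1 arises from compound 3 by hydrogen in place of chloro on an aromatic carbon, and this step is a 1.5-fold higher number from compound 3 to compound 1 (0.16 log units; within the scatter). Compound 2 and compound 3 hold the same atoms joined differently; the difference between the two cores is not broken down here. Compound 4 `ClCc1ccc(Cn2cnc3ncnc(Cl)c32)cc1` is not yet measured in this assay; it arises from compound 2 by hydrogen in place of chloro on an aromatic carbon, the same change as that from compound 3 to compound 1. Resting on the measured step of a 1.5-fold higher number from compound 3 to compound 1 (0.16 log units; within the scatter), a step of the same size is expected for the new pair, namely a 1.5-fold higher number from compound 2 to compound 4 (0.18 log units; within the scatter). Compound 4 is thus estimated at 3200 nM, with a likely range from 1500 nM to 7000 nM.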

Compound 4, concentration for 50% growth inhibition: 1810 nM
For compound 4 the middle estimate is 1.8-fold (0.25 log units) above the measured one; low and high end bracket the measured number.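

In this assay, hydrogen in place of chloro on the aromatic carbon between two ring nitrogen atoms gives a 1.2-fold lower number from compound 2 to compound 4 (0.07 log units; within the scatter), so on this core the change stays within the scatter. Set beside the earlier step, the change carries from one core to the other with no difference that can be told apart: the same change on two cores in this assay, a 1.5-fold higher number (0.16 log units; within the scatter) from compound 3 to compound 1 and a 1.2-fold lower number (0.07 log units; within the scatter) from compound 2 to compound 4, 1.7-fold (0.23 log units) apart, within the scatter of two such steps. This rests on two pairs only: it shows agreement between these two cores, but it does not show that the change would behave the same way on any other core in this series.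

The compounds shown leave open what an amine or a methoxy group would give at that carbon, where only hydrogen and chloro appear. They also leave open whether the step would hold if an amine replaced the remaining chloro group, meta to that carbon.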